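This account rests on a few compounds, and the source may have more. Where it says the series, first, only, none or still open, it means among the compounds named here.

Measured compounds:

Compound 1 `CCc1ccc(NCN2C(=O)c3ccccc3C2=O)cc1` — 63%
Compound 2 `CC(C)c1ccc(NCN2C(=O)c3ccccc3C2=O)cc1` — 46.5%
Compound 3 `COc1ccc(NCN2C(=O)c3ccc(NC(=O)c4ccccc4)cc3C2=O)cc1` — 82%

All three were tested in an assay on isolated protein for inhibition of ribosomal protein S6 kinase alpha-2 (Homo sapiens), read by fluorescence, with a stated time of 20 min, tested at 10 uM; on this read-out lower numbers stand for less inhibition and higher numbers for more inhibition at the one concentration tested (going by the name of the read-out). Compound 1 gives 63%, compound 2 gives 46.5%, and compound 3 gives 82%, the highest of the three numbers.

Compounds 1 and 2 differ by a single change, (methyl in place of hydrogen on a saturated chain carbon bound to an aromatic carbon and a saturated chain carbon), and that change produced a number 16.5 percentage points lower from compound 1 to compound 2 (beyond the scatter). Compound 3 is built on a different core from compound 1; the difference between the two cores is not broken down here.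

Compound 4 `CCOc1ccc(NCN2C(=O)c3ccc(NC(=O)c4ccccc4)cc3C2=O)cc1` has not yet been measured. It differs from compound 3 by methyl in place of hydrogen on a saturated chain carbon bound to an oxygen on an aromatic ring. This is the same kind of change as that from compound 1 to compound 2, but not the same: in the first pair the new methyl sits on a saturated chain carbon bound to an aromatic carbon and a saturated chain carbon, whereas in the second pair it sits on a saturated chain carbon bound to an oxygen on an aromatic ring.

Within the data shown here, the only guide is the first pair, where the change lowered inhibition in this assay by a modest amount beyond the scatter. If compound 3 behaves in the same way, a drop of similar size would be expected, though a different core and a different place leave room for doubt. The step expected from compound 3 to compound 4 is therefore a number 12 percentage points lower from compound 3 to compound 4 (beyond the scatter), resting on a number 16.5 percentage points lower from compound 1 to compound 2 (beyond the scatter). For compound 4 the estimated result in this assay is 70%, with a likely range from 52% to 86%.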

Compound 4, a percentage reported as inhibition, at one concentration (the size of the read-out at that concentration, not a potency): 69.5%
The estimate for compound 4 lay 0.5 percentage points above the measured number; the measured number falls inside the stated range.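

In this assay, the added methyl that turns 4-methoxyphenyl into 4-ethoxyphenyl gave a number 12.5 percentage points lower from compound 3 to compound 4 (beyond the scatter). Set beside the earlier step, the two drops cannot be told apart, so in these two pairs the added methyl goes with a modest loss of inhibition of similar size on both cores: the same change on two cores in this assay, a number 16.5 percentage points lower (beyond the scatter) from compound 1 to compound 2 and a number 12.5 percentage points lower (beyond the scatter) from compound 3 to compound 4, 4 percentage points apart, within the scatter of two such steps

Among these compounds, this is only two pairs, and the methyl does not sit in quite the same place in each: in the first it is on a saturated chain carbon bound to an aromatic carbon and a saturated chain carbon, and in the second on a saturated chain carbon bound to an oxygen on an aromatic ring. The agreement therefore does not show that the step would carry over to any other core, and it does not explain why the number falls.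

The compounds shown leave open whether a longer chain, such as propoxy or butoxy, in place of the ethoxy group of compound 4 would lower the number further. They also leave open what an amine or a carboxylic acid in that place would do, and how these single-concentration numbers relate to potency.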